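The source may report more compounds than this note shows. Statements on the series, on what has been measured and on what is new or still open speak of the compounds shown alone.

Working notes on the thiourea series.

Compound 1 `Oc1ccccc1NC(=S)Nc1ccc2[nH]ccc2c1` is measured in an ADME assay on cells for inhibition of Amine oxidase [flavin-containing] A (Homo sapiens), read by spectrophotometry (a lower number here means a stronger inhibitor, a higher number a weaker inhibitor), and gives 14000 nM. Compound 3 `Oc1cc(Cl)ccc1NC(=S)Nc1ccc2[nH]ccc2c1` differs from compound 1 by chloro in place of hydrogen on an aromatic carbon, and in this assay compound 3 gives 6300 nM; the step of a 2.2-fold lower number from compound 1 to compound 3 (0.35 log units; beyond the scatter) is modest but beyond the scatter. Compound 2 `Oc1ccc(NC(=S)Nc2ccc3[nH]ccc3c2)cc1Cl` gives 58000 nM in this assay, the highest number of the three; how its core differs from the core of compound 1 is not broken down here. Compound 4 `Oc1c(Cl)cc(NC(=S)Nc2ccc3[nH]ccc3c2)cc1Cl` is not yet measured; it differs from compound 2 by chloro in place of hydrogen on an aromatic carbon. The change is the same kind as that from compound 1 to compound 3, but not the same: in compound 3 the entering chloro sits meta to a hydroxy group and para to a large group, whereas in compound 4 it sits ortho to a hydroxy group, meta to a chloro group and meta to a large group. Among the compounds with values here, with only one measured instance of this kind of change, a step of similar size is expected; the step from compound 2 to compound 4 is estimated at a 1.9-fold lower number from compound 2 to compound 4 (0.29 log units; within the scatter), resting on a 2.2-fold lower number from compound 1 to compound 3 (0.35 log units; beyond the scatter). Compound 4 is thus expected to give about 30000 nM in this assay, within 12000 nM to 70000 nM.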

Compound 4, half-maximal inhibitory concentration: > 100000 nM
Compound 4 gave a limit, no number; the forecaster's own chance of this, stated with the estimate: 10%; middle value at least 3.3-fold (0.52 log units) away from the limit.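

In this assay compound 4 gives > 100000 nM, which is a limit of the assay and not a number. The new step is an at least 1.7-fold higher number from compound 2 to compound 4 (0.23 log units; that floor lies within the scatter), and chloro in place of hydrogen on an aromatic carbon does not give one shared step on the two cores, so the step seen on the core of compound 1 cannot simply be carried to the core of compound 2: the same change on two cores in this assay, a 2.2-fold lower number (0.35 log units; beyond the scatter) from compound 1 to compound 3 and an at least 1.7-fold higher number (0.23 log units; that floor lies within the scatter) from compound 2 to compound 4, at least 3.8-fold (0.58 log units) apart, beyond the scatter of two such steps. This does not show the true size of the new step, for which only a floor is known, nor does it give a reason for the difference, and each core supplies only one pair: the limit of > 100000 nM in this assay, at which 1 of the 4 values shown sits.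

The compounds shown leave open whether other groups in place of the entering chloro, such as fluoro, methyl or methoxy, would also differ between the two cores. From the compounds shown here alone, it also remains open whether the difference between the cores persists when the hydroxy group is replaced by an amine.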